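The source may hold more compounds than are shown below. What is called first, only, known or untested is meant among the compounds shown, and "the series" means these compounds.

The study concerns compound 1 `O=C1NCCc2nc(C#Cc3cccc(F)c3)sc21`, compound 2 `CC(C)CN1CCc2nc(C#Cc3ccccc3)sc2C1`, compound 3 `CCC(=O)N1CCc2nc(C#Cc3ccccc3)sc2C1` and the not yet measured compound 4 `O=C(C1CCCCC1)N1CCc2nc(C#Cc3ccccc3)sc2C1`. In an assay on HEK293 cells for negative allosteric modulation of metabotropic glutamate receptor 5 (Homo sapiens), read by FLIPR, with a stated time of 1 h (a lower number here means a stronger inhibitor, a higher number a weaker inhibitor), compound 1 gives only a limit, > 10000 nM. In this assay, within the data shown here, compound 2 gives 650 nM, the highest of the two numbers known so far, while compound 3 gives 38 nM. Among the measured compounds shown here, the single measured step between them, a 17-fold lower number from compound 2 to compound 3 (1.23 log units; beyond the scatter), comes from putting propanoyl in place of isobutyl on an amine nitrogen in a ring. Compound 4 differs from compound 2 at the same place: cyclohexylcarbonyl in place of isobutyl on an amine nitrogen in a ring. Both changes introduce a carbonyl on an amine nitrogen in a ring, so the measured step is the one that bears on the new compound, and a lowering of the number of comparable size, clearly beyond the scatter, is expected in this assay. The expected step is a 13-fold lower number from compound 2 to compound 4 (1.11 log units; beyond the scatter). Compound 4 is therefore estimated at 50 nM, with a range from 15 nM to 200 nM.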

Compound 4, half-maximal inhibitory concentration: > 10000 nM
Compound 4 gave a limit, no number (the forecaster's own chance of this, stated with the estimate: 3%); middle value at least 200-fold (2.30 log units) away from the limit.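

Compound 4 shows that a carbonyl on an amine nitrogen in a ring does not by itself lower the number in this assay: cyclohexylcarbonyl in place of isobutyl gives an at least 15-fold higher number from compound 2 to compound 4 (1.18 log units; beyond the scatter), against the opposite direction of a 17-fold lower number from compound 2 to compound 3 (1.23 log units; beyond the scatter). With the carbonyl kept, the group on the carbonyl carbon decides the outcome, as cyclohexyl in place of ethyl gives an at least 260-fold higher number from compound 3 to compound 4 (2.42 log units; beyond the scatter). Compound 4 gives a limit and not a number, so both new steps are minimum sizes: the limit of > 10000 nM in this assay, at which 2 of the 4 values shown sit.

The compounds shown leave open how the number moves with groups on the carbonyl carbon other than ethyl and cyclohexyl, such as cyclopropyl, isopropyl or phenyl. They also leave open whether an open chain such as hexyl on that carbon behaves like the cyclohexyl ring.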